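The source may report more compounds than this note shows. Statements on the series, on what has been measured and on what is new or still open speak of the compounds shown alone.

Measured compounds in an assay on isolated protein for inhibition of malate dehydrogenase, mitochondrial (Sus scrofa), with stated times of 45 min and 30 min; on this read-out higher numbers stand for weaker inhibition and lower numbers for stronger inhibition:
Compound 1 `O=S(=O)(Nc1ccc2oc(-c3ccccc3)nc2c1)c1ccccc1O` gives > 63000 nM, which is a limit of the assay and not a number.
Compound 2 `COc1ccc(Cl)cc1S(=O)(=O)Nc1ccc(-c2nc3ccccc3o2)cc1` gives > 63000 nM, also a limit rather than a number.
Compound 3 `O=S(=O)(Nc1ccc2oc(-c3ccccc3)nc2c1)c1cccc(C(F)(F)F)c1` gives > 63000 nM, again a limit and not a number.

All three values stand at the limit of > 63000 nM in this assay, at which 3 of the 3 values shown sit, so none of them shows measurable inhibition. Compound 2 therefore stands at the same place as the other two: no number exists for it, only the statement that the assay could not detect inhibition up to its ceiling.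

Compound 4 `COc1ccccc1S(=O)(=O)Nc1ccc(-c2nc3ccccc3o2)cc1` is the compound still to be measured. It comes from compound 2 by a single change: hydrogen in place of chloro on an aromatic carbon. The change is small in size, one heavy atom on an aromatic carbon, and leaves the rest of the molecule untouched.

For the measured compounds named here, no step between two measured compounds exists here, and every value shown is a limit. Nothing among these compounds gives a reason to expect a step beyond the usual scatter in this assay. Compound 4 is therefore expected to give 100000 nM, within 30000 nM to 300000 nM, most likely again as a limit. The step from compound 2 to compound 4 is estimated as a step that the limit leaves unreadable from compound 2 to compound 4, meaning no real change is expected.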

Compound 4, half-maximal inhibitory concentration: > 63000 nM
Compound 4 ended at the assay's limit; the forecaster's own chance of this, stated with the estimate: 85%; the middle value does not contradict the limit.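

Compound 2 and compound 4 both give limits rather than numbers in this assay, so no step can be read for the change from 5-chloro-2-methoxyphenyl to 2-methoxyphenyl: the limit of > 63000 nM in this assay, at which 4 of the 4 values shown sit.

The compounds shown leave open which structural change, if any, would bring a measurable value in this assay.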